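Chloro for trifluoromethyl on a geranyl-bearing pyridinone sulfonamide

The source may report more compounds than this note shows. Statements on the series, on what has been measured and on what is new or still open speak of the compounds shown alone.

Compound 1 `CC(C)=CCC1Cc2c(OCCCNS(=O)(=O)c3ccc(C(F)(F)F)cc3)cc(=O)n(CCCO)c2CC1(C)C` gives 0% in a functional assay on PANC-1 cells (Homo sapiens) for inhibition, read by MTT assay, with a stated time of 24 h, tested at 10 uM; on this read-out lower numbers stand for less inhibition and higher numbers for more inhibition at the one concentration tested (going by the name of the read-out). Compound 2 `CC(C)=CCC1Cc2c(OCCCNS(=O)(=O)c3ccc(Cl)cc3)cc(=O)n(CCCO)c2CC1(C)C` differs from it by chloro in place of trifluoromethyl on an aromatic carbon and gives 9.8%, a step of a number 9.8 percentage points higher from compound 1 to compound 2 (within the scatter). Compound 3 `CC(C)=CCC/C(C)=C/CC1Cc2c(OCCCNS(=O)(=O)c3ccc(C(F)(F)F)cc3)cc(=O)n(CCCO)c2CC1(C)C` differs from compound 1 by 3-methylbut-2-en-1-yl in place of hydrogen on a saturated chain carbon bound to a double-bonded chain carbon, a step of no change at the digits printed from compound 1 to compound 3 (within the scatter), and compound 3 gives 0%. Compound 4 `CC(C)=CCC/C(C)=C/CC1Cc2c(OCCCNS(=O)(=O)c3ccc(Cl)cc3)cc(=O)n(CCCO)c2CC1(C)C` is not yet measured; it differs from compound 3 by chloro in place of trifluoromethyl on an aromatic carbon, the same change that separates compound 1 from compound 2, made on the same place. Because compound 1 and compound 3 sit level at 0%, and because the earlier step was a number 9.8 percentage points higher from compound 1 to compound 2 (within the scatter), the expected step from compound 3 to compound 4 is a number 5 percentage points higher from compound 3 to compound 4 (within the scatter), a move that would stay within the scatter. Compound 4 is therefore estimated to give 5% in this assay.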

Compound 4, a percentage reported as inhibition, at one concentration (the size of the read-out at that concentration, not a potency): 16.1%
The estimate for compound 4 lay 11.1 percentage points below the measured number; measured number inside the range.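

In this assay, chloro in place of trifluoromethyl gave a number 16.1 percentage points higher from compound 3 to compound 4 (beyond the scatter), and this step agrees in size with the one on the core of compound 1: the same change on two cores in this assay, a number 9.8 percentage points higher (within the scatter) from compound 1 to compound 2 and a number 16.1 percentage points higher (beyond the scatter) from compound 3 to compound 4, 6.3 percentage points apart, within the scatter of two such steps. The 3-methylbut-2-en-1-yl change also gave a number 6.3 percentage points higher from compound 2 to compound 4 (within the scatter), which matches its effect in the trifluoromethyl pair: the same change on two cores in this assay, no change at the digits printed (within the scatter) from compound 1 to compound 3 and a number 6.3 percentage points higher (within the scatter) from compound 2 to compound 4, 6.3 percentage points apart, within the scatter of two such steps. Going by these compounds alone, this shows that both changes carried across these two cores within the scatter, but it does not show that they would carry to any other core, and only the step to compound 4 lies beyond the scatter, at a single concentration that gives no potency.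

The compounds shown leave open how a nitrile, a methoxy group or an amine would read on the same aromatic carbon. They also leave open whether a carboxylic acid in place of the terminal hydroxyl would alter these steps.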